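Cytotoxicity of three hydrazones and an untested bromophenyl analogue

The compounds below may be only part of what the source reports. "The series", "measured", "known", "first", "only" and "open" are said of these compounds alone.

The measured compounds and their values:
compound 1, `C/C(=N\NC(=O)COc1cccc2ccccc12)c1ccc(O)cc1`, 20 ug/mL
compound 2, `O=C(COc1cccc2ccccc12)N/N=C/c1ccccc1O`, 20 ug/mL
compound 3, `O=C(COc1cccc2ccccc12)N/N=C/c1c[nH]c2ccccc12`, 100 ug/mL

All three were tested in an ADME assay on HEL cells (Homo sapiens) for cytotoxicity; on this read-out lower numbers stand for higher toxicity in this test and higher numbers for lower toxicity in this test. Compound 1 gives 20 ug/mL, and compound 2 gives 20 ug/mL, so the two are level at the digits shown and lie within the scatter of each other; together they stand at the lowest of the three numbers. Compound 3 gives 100 ug/mL, a number that lies beyond the scatter above compound 1.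

The untested compound 4, `C/C(=N\NC(=O)COc1cccc2ccccc12)c1ccccc1Br`, shares its core with compound 1 and differs from it in one place:
2-bromophenyl in place of 4-hydroxyphenyl on a carbon with a double bond to nitrogen
For the measured compounds named here, no step between measured compounds covers a change of this kind, and nothing among the three values speaks for a change in either direction. The step is therefore expected to be small, no change at the digits printed from compound 1 to compound 4 (within the scatter), and to stay within the scatter. Compound 4 is estimated to give 20 ug/mL in this assay, with a range from 10 ug/mL to 50 ug/mL.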

Compound 4, minimum cytotoxic concentration: 20 ug/mL
Beside the measured number, compound 4's estimate shows no gap at the digits printed; measured number inside the range.
By their numbers in this assay, from the lowest: compounds 1, 2 and 4 (each within the scatter of the next); then compound 3.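

For the compounds shown here, this is the first step at this position, on a carbon with a double bond to nitrogen, and in this assay placing 2-bromophenyl there in place of 4-hydroxyphenyl gives no change at the digits printed from compound 1 to compound 4 (within the scatter). The entering group keeps the count of 7 heavy atoms and the six-membered aromatic ring of carbon only, but it carries 0 hydrogen-bond donors and 0 hydrogen-bond acceptors where the leaving group carried 1 of each, so for this pair the read-out does not depend on the donor and acceptor of 4-hydroxyphenyl. No measurement at hand accounts for this result.

The step alters two things at once, the atom on the ring (bromine for oxygen) and the number it carries in the group's name, so this single pair cannot separate the two. From the compounds shown here alone, whether the number in this assay would also hold with a plain phenyl at this carbon, or with an amine or a carboxylic acid on that ring, stays open.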